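Notes on compound 2 and its pyridin-3-yl isomer

A few compounds are considered here, and "the series" means these few. Any claim that something is new, unique, unknown or untested is made for them only; others in the source may bear on it.

Three compounds carry results in an ADME assay on microsomes from liver (Mus musculus) for metabolic stability, using NADPH, with a stated time of 60 min; on this read-out lower numbers stand for slow clearance and higher numbers for fast clearance. Compound 2 `O=C(Nc1ccc(F)c(C(F)(F)F)c1)Nc1ccccn1` gives 705 uL/min in this assay, the highest of the two numbers available; compound 3 `O=C(Nc1cnccn1)Nc1cnccn1` gives 157 uL/min, and the gap between these two lies beyond the usual scatter. Compound 1 `N#Cc1ccc(NC(=O)Nc2ccnc(C(F)(F)F)c2)cc1` returns < 7 uL/min in this assay, which is a limit of the assay and not a number. That reading is the limit of < 7 uL/min in this assay, at which 1 of the 3 values shown sits.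

Compound 4 `O=C(Nc1cccnc1)Nc1ccc(F)c(C(F)(F)F)c1` has not yet been measured. It differs from compound 2 in one place, the two having the same atoms joined differently: pyridin-3-yl in place of pyridin-2-yl on an amide-type nitrogen. Going by the values given here, no measured pair in this set shows the same change, so nothing here fixes the size or direction of the step in this assay; a step of modest size in either direction, and possibly none beyond the scatter, is expected. Compound 4 is expected to give 500 uL/min in this assay, with a range from 200 uL/min to 1200 uL/min. The expected step of a 1.4-fold lower number from compound 2 to compound 4 (0.15 log units; within the scatter) stays within the scatter of repeated measurements.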

Compound 4, intrinsic clearance in a liver preparation (reported as CLH), per the amount of preparation that the assay uses in the Mus musculus assay: 154 uL/min
Estimate against measurement, compound 4: 3.2-fold (0.51 log units) above, and the stated range ends above it.
By their numbers in the Mus musculus assay, from the lowest: compounds 4 and 3 (each within the scatter of the next); then compound 2. At a limit, below all of these: compound 1.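

In the Mus musculus assay, pyridin-3-yl in place of pyridin-2-yl on an amide-type nitrogen gives a 4.6-fold lower number from compound 2 to compound 4 (0.66 log units; beyond the scatter), so clearance at this position differs between two compounds with the same atoms, joined differently. In a physicochemical assay for solubility, read by nephelometry, measured as kinetic solubility, at pH 2 (on this read-out lower numbers stand for lower solubility and higher numbers for higher solubility), compound 2 gives 1.6 ug/mL and compound 4 gives 50 ug/mL, so the two isomers also part on this second read-out. Going by these compounds alone, no earlier pair differed in one place, which makes this the first step that can be read.

Going by these compounds, how pyridin-4-yl, or a phenyl carrying a carboxylic acid, would read at this place in the Mus musculus assay stays open. Within the data shown here, with only this one pair, it also stays open whether the step carries over to another core.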